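Swapping Methoxy for Cyano: What Compound 4 Should Show

The source may report more compounds than this note shows. Statements on the series, on what has been measured and on what is new or still open speak of the compounds shown alone.

Compound 3 `COc1ccc(-c2csc(N3C(=O)c4ccc(F)cc4C3=O)n2)cc1` gives 41300 nM in a functional assay on PC-3 cells (Homo sapiens) for antiproliferative activity, read by MTT assay, with a stated time of 48 h (on this read-out lower numbers stand for stronger inhibition and higher numbers for weaker inhibition), the highest of three numbers, yet compound 1 `N#Cc1ccc(-c2csc(N3C(=O)c4ccccc4C3=O)n2)cc1` gives 40300 nM and compound 2 `O=C1c2ccc(F)cc2C(=O)N1c1nc(-c2ccc(F)cc2)cs1` gives 39500 nM, both within the scatter of it. Within the data shown here, the one measured step, a 1.0-fold higher number from compound 2 to compound 3 (0.02 log units; within the scatter), shows a swap of one group for another on that aromatic carbon leaving the number essentially unchanged. Compound 4 `N#Cc1ccc(-c2csc(N3C(=O)c4ccc(F)cc4C3=O)n2)cc1` is compound 3 with cyano in place of methoxy on an aromatic carbon. Compound 1 bears a cyano group too, and its value sits beside those of compounds 2 and 3. Among the measured compounds shown here, no measured step bears directly on this swap, so the expected step is small, a 1.0-fold lower number from compound 3 to compound 4 (0.01 log units; within the scatter), in no firm direction. Compound 4 is therefore expected to give about 40000 nM, between 20000 nM and 80000 nM.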

Compound 4, half-maximal inhibitory concentration: 43100 nM
For compound 4 the middle estimate is 1.1-fold (0.03 log units) below the measured one, within the range that was stated.
By their numbers in this assay, from the lowest: compounds 2, 1, 3 and 4 (each within the scatter of the next).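

In this assay, cyano on this aromatic carbon reads the same as methoxy and fluoro, with a 1.0-fold higher number from compound 3 to compound 4 (0.02 log units; within the scatter) and a 1.1-fold higher number from compound 2 to compound 4 (0.04 log units; within the scatter) both within the scatter. Among these compounds, a second aromatic carbon also shows nothing for its one change, with a 1.1-fold higher number from compound 1 to compound 4 (0.03 log units; within the scatter) likewise within the scatter. No measured evidence explains why these numbers stay level. As far as these compounds go, whether an amine or a carboxylic acid at the position of the methoxy group would move the number remains open.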